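Propanoyl Amide in Place of Methyl on the Ring Amine

The source may report more compounds than this note shows. Statements on the series, on what has been measured and on what is new or still open speak of the compounds shown alone.

Compound 2 `CN1CCc2nc(C#Cc3ccccc3)sc2C1` was tested in an assay on HEK293 cells for negative allosteric modulation of metabotropic glutamate receptor 5 (Homo sapiens), read by FLIPR, with a stated time of 1 h; a lower number here means a stronger inhibitor, a higher number a weaker inhibitor. Compound 2 gave only > 10000 nM, which is a limit of the assay rather than a measured number. Compound 1 `O=C1NCCc2nc(C#Cc3ccccc3F)sc21` is a related member of the same core. Compound 1 likewise returned only > 10000 nM, again a limit and not a number. Within the data shown here, both results therefore sit at the limit of > 10000 nM in this assay, at which 2 of the 2 values shown sit, so no step between measured compounds can be sized here, and nothing yet shows how any change on the shared core moves the result.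

Compound 3 `CCC(=O)N1CCc2nc(C#Cc3ccccc3)sc2C1` differs from compound 2 in one place: propanoyl in place of methyl on an amine nitrogen in a ring. Among the measured compounds shown here, no measured pair shows what such a change does, so any expectation rests on the two limits alone and carries real doubt. The expected step is an at least 5.0-fold lower number from compound 2 to compound 3 (0.69 log units; beyond the scatter), toward a stronger inhibitor, but only as a guess. For compound 3 the estimate in this assay is 2000 nM, expected to fall between 300 nM and 12000 nM, with a fair chance that only a limit is reported again.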

Compound 3, half-maximal inhibitory concentration: 38 nM
Compound 3: the middle estimate sits 53-fold (1.72 log units) above what was measured; the whole stated range lies above it.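

At this amine nitrogen in a ring, the group attached turns out to matter a great deal: in this assay, propanoyl in place of methyl gives an at least 260-fold lower number from compound 2 to compound 3 (2.42 log units; beyond the scatter), toward a stronger inhibitor. This is the first step on the shared core that can be sized at all, and compound 3 is the first compound shown with a real number rather than a limit, so this position is clearly one where a change can switch on measurable activity. The step is only a minimum, as its starting point, compound 2, holds a limit and not a number: the limit of > 10000 nM in this assay, at which 2 of the 3 values shown sit.

This one pair cannot separate the carbonyl that enters from the longer carbon chain, and an acetyl group or a plain propyl chain on the same nitrogen would be needed to tell the two apart. Any other steps involving compound 1 cannot be read, since it differs from compound 2 and compound 3 in more than one place, so the effect of its other features remains unknown.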